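The source may report more compounds than this note shows. Statements on the series, on what has been measured and on what is new or still open speak of the compounds shown alone.

Compound 1 `CC[C@H](NC(C)=O)c1cc(Cl)ccc1C1CCN(C(=O)[C@@H]2CN(C(C)(C)C)C[C@H]2c2ccc(F)cc2Cl)CC1` is measured in a functional assay on CHO cells for agonist activity at Melanocortin receptor 4 (Homo sapiens), read by cAMP accumulation (on this read-out higher numbers stand for larger maximal responses and lower numbers for smaller maximal responses), where compound 1 gives 84%. Compound 2 `CC[C@H](NC(C)=O)c1cc(Cl)ccc1C1CCN(C(=O)[C@H]2CN(C(C)(C)C)C[C@@H]2c2ccc(Cl)cc2F)CC1` shares the same core, and in this assay compound 2 gives 45%. Of these two numbers, compound 1 stands highest, with compound 2 lower by a gap beyond the usual scatter. Compound 3 `CC[C@H](NC(C)=O)c1cc(Cl)ccc1C1CCN(C(=O)[C@@H]2CN(C(C)(C)C)C[C@H]2c2ccc(C(F)(F)F)cc2F)CC1` is not yet measured. It differs from compound 1 in one place: 2-fluoro-4-(trifluoromethyl)phenyl in place of 2-chloro-4-fluorophenyl on a saturated ring carbon. Going by the values given here, no measured pair shows how such a change plays out, so the expectation rests on compound 1 alone. Compound 3 is expected to give about 75%, between 50% and 95%. The expected step of a number 9 percentage points lower from compound 1 to compound 3 (within the scatter) is a small drop that may stay within the scatter.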

Compound 3, largest response reached (reported as percent of maximum), in percent of the reference or control that the assay uses: 99%
Estimate against measurement, compound 3: 24 percentage points below, and the stated range ends below it.
By their numbers in this assay, from the lowest: compound 2; then compound 1; then compound 3.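

In this assay, this position on the saturated ring carbon accepts the larger 2-fluoro-4-(trifluoromethyl)phenyl group in place of 2-chloro-4-fluorophenyl, giving a number 15 percentage points higher from compound 1 to compound 3 (beyond the scatter). Both ring substituents differ in this single swap, so the step cannot show which of them accounts for the rise. Nothing measured here explains the rise. Still open, as far as these compounds go, is whether a nitrile or a methoxy group in place of the trifluoromethyl would keep this response, and how a single halogen change on this ring would read.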